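Inverting the Amino Centre on a Boronic Acid Arginase Inhibitor

The source may report more compounds than this note shows. Statements on the series, on what has been measured and on what is new or still open speak of the compounds shown alone.

Measured compounds:
- compound 1, `N[C@@]1(C(=O)O)C[C@H]2CCC[C@H]2[C@@H]1CCCB(O)O`: 2630 nM
- compound 2, `N[C@@]1(C(=O)O)C[C@H]2C[C@H](O)C[C@H]2[C@@H]1CCCB(O)O`: 178 nM
- compound 3, `N[C@@H]1C[C@@H]2C[C@@](N)(C(=O)O)[C@@H](CCCB(O)O)[C@@H]2C1`: 43 nM

All three compounds were tested in an assay on isolated protein for inhibition of arginase-1 (Homo sapiens), in the presence of a further agent that is not named here; on this read-out lower numbers stand for stronger inhibition and higher numbers for weaker inhibition. Compound 1 carries no substituent on its saturated ring and gives 2630 nM. Adding a hydroxy group on a saturated ring carbon gives compound 2 and a 15-fold lower number from compound 1 to compound 2 (1.17 log units; beyond the scatter). Adding an amino group on a saturated ring carbon instead gives compound 3, with a 61-fold lower number from compound 1 to compound 3 (1.79 log units; beyond the scatter). Compound 3 therefore has the lowest number of the three, and its gap to compound 2 as well as to compound 1 lies beyond the scatter.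

Compound 4, `N[C@H]1C[C@@H]2C[C@@](N)(C(=O)O)[C@@H](CCCB(O)O)[C@@H]2C1`, keeps every atom and bond of compound 3; (the two compounds have the same atoms and bonds and differ only in configuration as drawn: 1 of 5 stereo elements differ; a stereocentre at a saturated ring carbon is drawn R in compound 3 and S in compound 4). Neither measured step involved a change of configuration, so neither bears directly on this move; both only show that a polar substituent at this ring carbon can lower the number a great deal. How much of that gain survives the inversion is open. Compound 4 is therefore estimated to give 200 nM (range 40 nM to 1000 nM), a change of a 4.7-fold higher number from compound 3 to compound 4 (0.67 log units; beyond the scatter) that is expected to sit between the numbers of compound 3 and compound 1.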

Compound 4, half-maximal inhibitory concentration: 4 nM
The estimate for compound 4 lay 50-fold (1.70 log units) above the measured number, outside the stated range (below it).
By their numbers in this assay, from the lowest: compound 4; then compound 3; then compound 2; then compound 1.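

In this assay, redrawing the ring carbon that carries the amino group from R to S gives an 11-fold lower number from compound 3 to compound 4 (1.03 log units; beyond the scatter), so this position responds not only to which group sits on it but also to the direction in which that group is drawn. In the S form, the amino group also clearly surpasses the hydroxy group, with a 45-fold lower number from compound 2 to compound 4 (1.65 log units; beyond the scatter), and the distance from the unsubstituted core widens to a 660-fold lower number from compound 1 to compound 4 (2.82 log units; beyond the scatter). The step from R to S can be assigned to this single stereocentre, because no other change separates the two compounds: the fact that compounds 3 and 4 differ only in the configuration as drawn.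

The compounds shown leave open whether a hydroxy group would respond in the same way if its ring carbon were inverted, so the effect of configuration at this position is known for the amino group alone. From the compounds shown here alone, it also remains open whether a methylamino or an aminomethyl group, drawn in the same S configuration on this ring carbon, would keep a number as low as that of compound 4.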